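Cytotoxicity limits across a series of biaryl amides

The compounds below may be only part of what the source reports. "The series", "measured", "known", "first", "only" and "open" are said of these compounds alone.

Compound 1 `CCOC(=O)CCCCCOc1cccc(CN(C(=O)c2ccc(-c3ccoc3)cc2)C(C)C)c1`: in an ADME assay on HEK293 cells (Homo sapiens) for cytotoxicity, read by CellTiter-Glo and resazurin assay, with a stated time of 72 h (a higher number here means that more compound is needed for the effect, a lower number that less compound is needed), compound 1 reaches only the assay limit, > 26000 nM.
Compound 2 `CCOC(=O)CCCCCOc1cccc(CN(C(=O)c2ccc(-c3cccc(OC(C)C)c3)cc2)C(C)C)c1`: in this assay compound 2 likewise reaches only the limit, > 26000 nM.
Compound 3 `CCOC(=O)CCCCCOc1cccc(CN(C(=O)c2ccc(-c3ccco3)cc2)C(C)C)c1`: in this assay compound 3 again reaches only the limit, > 26000 nM.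

Compound 3 thus stands at the same limit as every other value shown (the limit of > 26000 nM in this assay, at which 3 of the 3 values shown sit). Compound 4 `CCOC(=O)CCCCCOc1cccc(CN(C(=O)c2ccc(-c3cccc(OC)c3)cc2)C(C)C)c1` differs from it in one place: 3-methoxyphenyl in place of furan-2-yl on an aromatic carbon. The steps that touch this position, a step that the two limits leave unreadable from compound 1 to compound 3 and a step that the two limits leave unreadable from compound 2 to compound 3, cannot be sized, since both ends sit at the limit; the step that the two limits leave unreadable from compound 1 to compound 2 is equally unreadable. Going by the values given here, no measured step therefore points to a direction for this assay, and a result at the limit again is the expectation. Compound 4 is accordingly estimated at 30000 nM, within 12000 nM to 90000 nM, an expected step that the limit leaves unreadable from compound 3 to compound 4.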

Compound 4, half-maximal effective concentration: > 21000 nM
Compound 4 ended at the assay's limit; the forecaster's own chance of this, stated with the estimate: 80%; the middle value does not contradict the limit.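

In this assay, going by these compounds alone, compound 4, like compound 1, compound 2 and compound 3, gives only a limit, and no step among them can be read. The compounds shown leave open whether any of these aromatic groups changes the cytotoxicity.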